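A Methyl Added Again on a Chloro-Bearing Core

The compounds below may be only part of what the source reports. "The series", "measured", "known", "first", "only" and "open" are said of these compounds alone.

Compound 1 `Cc1ccc(-c2csc(NC(=O)COc3ccccc3)n2)cc1`, compound 2 `Cc1ccc(-c2csc(NC(=O)COc3ccccc3C)n2)cc1` and compound 3 `O=C(COc1ccccc1)Nc1nc(-c2ccc(Cl)cc2)cs1` share a core and were tested in a functional assay on MDA-MB-468 cells (Homo sapiens) for cytotoxicity, read by trypan blue exclusion, with a stated time of 48 h; a lower number here means a stronger inhibitor, a higher number a weaker inhibitor. In this assay compound 1 gives 54500 nM, compound 2 gives 51700 nM and compound 3 gives 44200 nM. From compound 1 to compound 2 the change is methyl in place of hydrogen on an aromatic carbon, and it made a 1.1-fold lower number from compound 1 to compound 2 (0.02 log units; within the scatter). Compound 3 differs from compound 1 by chloro in place of methyl on an aromatic carbon, which gave a 1.2-fold lower number from compound 1 to compound 3 (0.09 log units; within the scatter). Compound 4 `Cc1ccccc1OCC(=O)Nc1nc(-c2ccc(Cl)cc2)cs1` has not been measured; it carries the same change on the core of compound 3, namely (methyl in place of hydrogen on an aromatic carbon). Because a 1.1-fold lower number from compound 1 to compound 2 (0.02 log units; within the scatter), an equally small step is expected this time, a 1.1-fold lower number from compound 3 to compound 4 (0.03 log units; within the scatter). Compound 4 is therefore estimated at 41000 nM, most likely falling between 20000 nM and 85000 nM.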

Compound 4, half-maximal inhibitory concentration: 52100 nM
Compound 4: middle estimate off by 1.3-fold (0.10 log units), on the low side, and the stated range covers the measured number.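

In this assay, methyl in place of hydrogen on an aromatic carbon gave a 1.2-fold higher number from compound 3 to compound 4 (0.07 log units; within the scatter), and this agrees with the earlier step on the other core: the same change on two cores in this assay, a 1.1-fold lower number (0.02 log units; within the scatter) from compound 1 to compound 2 and a 1.2-fold higher number (0.07 log units; within the scatter) from compound 3 to compound 4, 1.2-fold (0.09 log units) apart, within the scatter of two such steps

Chloro in place of methyl on an aromatic carbon gave a 1.0-fold higher number from compound 2 to compound 4 (0.00 log units; within the scatter), and this agrees with its earlier counterpart too: the same change on two cores in this assay, a 1.2-fold lower number (0.09 log units; within the scatter) from compound 1 to compound 3 and a 1.0-fold higher number (0.00 log units; within the scatter) from compound 2 to compound 4, 1.2-fold (0.09 log units) apart, within the scatter of two such steps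

Going by these compounds alone, every one of these steps lies within the scatter, so the agreement shows only that neither change made a measurable difference on these cores; it does not show that a real effect carries from one core to another.

Still open, as far as these compounds go, is whether an amine or a carboxylic acid in place of the methyl would produce a step beyond the scatter. If one did, it could then be tested whether that larger step also carries across both cores.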